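The source may hold more compounds than are shown below. What is called first, only, known or untested is meant among the compounds shown, and "the series" means these compounds.

Measured in a physicochemical assay for metabolic stability, read by HPLC and mass spectrometry, in phosphate buffer, at 37 degrees C, at pH 7.4; a higher number here means that the compound lasts longer, a lower number that the compound disappears faster:
- compound 1 `CC(C)(O/N=C(\C(=O)N[C@@H]1C(=O)N(S(=O)(=O)O)[C@@H]1CN1CCCC1=O)c1csc(N)n1)C(=O)O`: > 1000 h (a limit)
- compound 2 `CC(C)(O/N=C(\C(=O)N[C@@H]1C(=O)N(S(=O)(=O)O)[C@@H]1CN1CCCCC1=O)c1csc(N)n1)C(=O)O`: 214 h
- compound 3 `CC(C)(O/N=C(\C(=O)N[C@@H]1C(=O)N(S(=O)(=O)O)[C@@H]1CN1CCNC1=O)c1csc(N)n1)C(=O)O`: > 1000 h (a limit)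

Compound 3 is known only through a limit, > 1000 h. Compound 3 and compound 1 both sit at the limit of > 1000 h in this assay, at which 2 of the 3 values shown sit. The comparison of the two gives a step that the two limits leave unreadable from compound 1 to compound 3. Compound 2 is the only one of the three with a number, and the two readable steps both involve it: an at least 4.6-fold lower number from compound 1 to compound 2 (0.66 log units; beyond the scatter) and an at least 4.6-fold higher number from compound 2 to compound 3 (0.66 log units; beyond the scatter).

Compound 4 `CC(C)(O/N=C(\C(=O)N[C@@H]1C(=O)N(S(=O)(=O)O)[C@@H]1Cn1ccnn1)c1csc(N)n1)C(=O)O` carries 1H-1,2,3-triazol-1-yl in place of 2-oxoimidazolidin-1-yl on a saturated chain carbon bound to a saturated ring carbon. A five-membered non-aromatic ring leaves and a five-membered aromatic ring enters. Within the data shown here, no measured step brings in an aromatic ring, so the steps bear on this change only loosely. They do show, with compound 2 at 214 h, that a swap at this place can give a readable fall in this assay. A modest fall is therefore expected, though the result may equally stay at the limit. The expected change is an at least 2.8-fold lower number from compound 3 to compound 4 (0.45 log units; beyond the scatter). For compound 4 the estimated half-life is 350 h, with an expected range from 80 h to 1000 h.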

Compound 4, half-life: 257 h
Beside the measured number, compound 4's estimate is 1.4-fold (0.13 log units) above it, and the stated range covers the measured number.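

In this assay, 1H-1,2,3-triazol-1-yl on a saturated chain carbon bound to a saturated ring carbon shows that a readable fall at this place is not confined to 2-oxopiperidin-1-yl, with an at least 3.8-fold lower number from compound 3 to compound 4 (0.59 log units; beyond the scatter) and an at least 3.8-fold lower number from compound 1 to compound 4 (0.59 log units; beyond the scatter). Set against 2-oxopiperidin-1-yl, the aromatic ring gives a 1.2-fold higher number from compound 2 to compound 4 (0.08 log units; within the scatter), so the non-aromatic six-membered lactam and the aromatic triazole cannot be told apart in this assay. Compound 1 and compound 3 remain known only through a limit, so the steps to them fix only a smallest size and the step between them cannot be read: the limit of > 1000 h in this assay, at which 2 of the 4 values shown sit.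

Compound 4 loses the ring carbonyl and the hydrogen-bond donor and gains an aromatic ring in a single step, so the compounds shown do not separate these changes as the feature that goes with the fall. From the compounds shown here alone, how an isomeric 2H-1,2,3-triazol-2-yl, a tetrazol-1-yl or an open-chain acetamide would read at this place remains open, as does the real distance between compound 1 and compound 3.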